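Azole swap toward compound 4: isobutyl thiadiazole

The source may hold more compounds than are shown below. What is called first, only, known or untested is meant among the compounds shown, and "the series" means these compounds.

Going by the values given here, compound 3 `CC(C)(C)c1nnc(-c2ccc(N3CCC(Oc4ccccc4C(F)(F)F)CC3)nn2)o1` gives 980 nM in an assay on microsomes from liver for inhibition of acyl-CoA desaturase 1 (Rattus norvegicus) (a higher number here means a weaker inhibitor, a lower number a stronger inhibitor), the highest of the three numbers measured so far. Compound 1 `OCc1nnc(-c2ccc(N3CCC(Oc4ccccc4C(F)(F)F)CC3)nn2)s1` gives 3.2 nM in this assay, and compound 2 `Oc1nnc(-c2ccc(N3CCC(Oc4ccccc4C(F)(F)F)CC3)nn2)s1` gives 6.1 nM. The step of a 1.9-fold higher number from compound 1 to compound 2 (0.28 log units; within the scatter) lies within the scatter. The steps onto compound 3 are both large: a 310-fold higher number from compound 1 to compound 3 (2.49 log units; beyond the scatter) and a 160-fold higher number from compound 2 to compound 3 (2.21 log units; beyond the scatter). Compound 4 `CC(C)Cc1nnc(-c2ccc(N3CCC(Oc4ccccc4C(F)(F)F)CC3)nn2)s1` has not been measured. The change is 5-isobutyl-1,3,4-thiadiazol-2-yl in place of 5-(tert-butyl)-1,3,4-oxadiazol-2-yl on an aromatic carbon. Both measured steps onto compound 3 alter the ring heteroatom and the substituent at the same time, so the contribution of the sulfur-containing ring cannot be separated from that of the hydroxy or hydroxymethyl group. Among the compounds with values here, compound 4 restores the sulfur ring but carries an isobutyl group, which no measured compound has, so the number is expected to fall well short of the level of compound 1 and compound 2. The expected step is a 16-fold lower number from compound 3 to compound 4 (1.21 log units; beyond the scatter). For compound 4 the estimate in this assay is 60 nM, with a range from 8 nM to 400 nM.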

Compound 4, half-maximal inhibitory concentration: 37 nM
Compound 4: middle estimate off by 1.6-fold (0.21 log units), on the high side; low and high end bracket the measured number.
By their numbers in this assay, from the lowest: compounds 1 and 2 (each within the scatter of the next); then compound 4; then compound 3.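

In this assay, the swap of the ring and its alkyl group (a 26-fold lower number from compound 3 to compound 4 (1.42 log units; beyond the scatter)) shows that a 1,3,4-thiadiazol-2-yl ring carrying only an isobutyl group, with no hydroxy or hydroxymethyl, already gives a much lower number than the tert-butyl oxadiazole. That group does not match the two oxygen-bearing substituents on the same ring, as the steps to isobutyl show (a 6.1-fold higher number from compound 2 to compound 4 (0.78 log units; beyond the scatter)) and (a 12-fold higher number from compound 1 to compound 4 (1.06 log units; beyond the scatter)), so the substituent on the sulfur ring matters in its own right. No measurement here gives a reason for any of these steps.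

The ring atom and the shape of the alkyl group still change together between compound 3 and compound 4, so a 5-isobutyl-1,3,4-oxadiazol-2-yl or a 5-(tert-butyl)-1,3,4-thiadiazol-2-yl group would be needed to separate them. On these data alone, how a primary amine or a carboxylic acid on the 1,3,4-thiadiazol-2-yl ring compares with hydroxy and hydroxymethyl remains open.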